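Trifluoromethyl on the triazole-side carbon: a cytotoxicity estimate

This account rests on a few compounds, and the source may have more. Where it says the series, first, only, none or still open, it means among the compounds named here.

Measured in an ADME assay on MDCK cells (Canis lupus familiaris) for cytotoxicity; a lower number here means that less compound is tolerated, a higher number that more compound is tolerated:
- compound 1 `O=[N+]([O-])C1=CNc2nc(C(F)(F)F)nn2C1c1ccc(O)c(O)c1`: 1210000 nM
- compound 2 `O=[N+]([O-])C1=CNc2nc(-c3ccco3)nn2C1c1ccc(O)c(O)c1O`: 317000 nM
- compound 3 `O=[N+]([O-])C1=CNc2ncnn2C1c1ccc(O)c(O)c1O`: 405000 nM

Compound 3 gives 405000 nM and lies within the scatter of compound 2 at 317000 nM on this read-out. Compound 1 gives 1210000 nM in the same assay. Going by the values given here, that number stands higher than the one of compound 3, and the gap between the two lies beyond the scatter.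

The next compound is compound 4 `O=[N+]([O-])C1=CNc2nc(C(F)(F)F)nn2C1c1ccc(O)c(O)c1O`, which carries trifluoromethyl in place of hydrogen on an aromatic carbon and otherwise matches compound 3.

Among the compounds with values here, one measured step touches that carbon: a 1.3-fold higher number from compound 2 to compound 3 (0.11 log units; within the scatter) with a different group, and it stays within the scatter. Compound 1 also bears trifluoromethyl there, but it differs from compound 4 elsewhere as well, so its value cannot be assigned to that group alone. It still gives a weak hint upward. In this assay a small upward step is therefore expected, most likely not beyond the scatter. The estimated step is a 1.3-fold higher number from compound 3 to compound 4 (0.11 log units; within the scatter) and it remains an expectation resting on very few data. Compound 4 is estimated at 520000 nM with an expected range from 260000 nM to 1100000 nM.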

Compound 4, half-maximal cytotoxic concentration: 373000 nM
Compound 4: middle estimate off by 1.4-fold (0.14 log units), on the high side; low and high end bracket the measured number.
By their numbers in this assay, from the lowest: compounds 2, 4 and 3 (each within the scatter of the next); then compound 1.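

On an aromatic carbon of the five-membered aromatic ring, between two ring nitrogen atoms, this assay does not separate trifluoromethyl from hydrogen (a 1.1-fold lower number from compound 3 to compound 4 (0.04 log units; within the scatter)) or trifluoromethyl from furan-2-yl (a 1.2-fold higher number from compound 2 to compound 4 (0.07 log units; within the scatter)), so all three groups now sit within the scatter of one another at this carbon. Going by these compounds alone, the one clear shift involving compound 4 lies elsewhere, with hydroxy in place of hydrogen on an aromatic carbon (a 3.2-fold lower number from compound 1 to compound 4 (0.51 log units; beyond the scatter)), which shows that the high number of compound 1 does not follow from trifluoromethyl alone and goes with the change on the other ring. No supporting measurement accounts for either the flat response at this carbon or the shift from the added hydroxy.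

Whether an amine, a carboxylic acid or a longer alkyl chain at the same carbon would also leave this read-out unchanged remains open, since the three groups shown span only a narrow set. As far as these compounds go, it is equally open whether the hydroxy step holds with hydrogen or furan-2-yl at that carbon, as this step is read only once, with trifluoromethyl in place.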